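Hydroxy on the outer ring of compound 1

The compounds below may be only part of what the source reports. "The series", "measured", "known", "first", "only" and "open" are said of these compounds alone.

Measured compounds:
compound 1 `Oc1ccccc1CNc1ccc(-c2ccccc2)cc1`: 1820 nM
compound 2 `Oc1ccccc1CNc1ccc(-c2ccc(-c3ccccc3)cc2)cc1`: "not active" (no number reported), no number reported
compound 3 `CCOc1ccc(-c2ccc(NCc3ccccc3O)cc2)cc1`: 520 nM

All numbers come from a functional assay on Jurkat cells (Homo sapiens) for activation, with a stated time of 24 h; on this read-out lower numbers stand for an effect already at smaller amounts and higher numbers for an effect only at larger amounts of compound. Compound 1 stands highest of the two numbers in this assay; the nearest entry is compound 3, and the step of a 3.5-fold lower number from compound 1 to compound 3 (0.54 log units; beyond the scatter) lies beyond the scatter. Compound 2 returned no number at all in this assay.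

The change to compound 4 `Oc1cccc(-c2ccc(NCc3ccccc3O)cc2)c1` is hydroxy in place of hydrogen on an aromatic carbon: the entering group carries one hydrogen-bond donor and one hydrogen-bond acceptor, sits meta to a large group on the outer six-membered ring of carbon only, and read one bond further out the difference is phenyl to 3-hydroxyphenyl.

Among the compounds with values here, only one measured step bears on this: a 3.5-fold lower number from compound 1 to compound 3 (0.54 log units; beyond the scatter), where a substituent on the same outer ring gave a modest lowering. Compound 2, where a further ring enters instead, gave no number. A hydroxy group is a different substituent from ethoxy, so the expected step of a 1.8-fold lower number from compound 1 to compound 4 (0.26 log units; within the scatter) is a modest lowering at most, possibly none beyond the scatter. Compound 4 is therefore estimated at 1000 nM, with a range from 350 nM to 2800 nM in this assay.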

Compound 4, half-maximal effective concentration: "not active" (no number reported)
Nothing numeric was reported for compound 4; the estimate stays without a comparison.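

In this assay compound 4 gave no number, so no step can be read from compound 1 to compound 4 or between compound 4 and any other compound shown. No measurement available here bears on this result. The compounds shown leave open which outer-ring substituents other than ethoxy retain a numeric read-out.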